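Working notes: from compound 3 to compound 4

The source may hold more compounds than are shown below. What is called first, only, known or untested is meant among the compounds shown, and "the series" means these compounds.

In a functional assay on LoVo cells (Homo sapiens) for cytotoxicity, read by colorimetric assay and MTT assay (a lower number here means a stronger inhibitor, a higher number a weaker inhibitor), compound 3 (`COc1ccc(-c2cc3c(OC)cc(OC)cc3n(CCCC#N)c2=O)cc1`) reads 10000 nM and stands level with compound 1 (`CCN(CC)C(=O)Cn1c(=O)c(-c2ccc(OC)cc2)cc2c(OC)cc(OC)cc21`) at 10000 nM and compound 2 (`COc1ccc(-c2cc3c(OC)cc(OC)cc3n(CC#N)c2=O)cc1`) at 10000 nM on the same read-out. Compound 4 (`COc1ccc(-c2cc3c(OC)cc(OC)cc3n(CC(=O)OCc3ccccc3)c2=O)cc1`) carries benzyloxycarbonyl in place of 2-cyanoethyl on a saturated chain carbon bound to an aromatic nitrogen. Three measured swaps at this place bear on it, with no change at the digits printed from compound 1 to compound 2 (within the scatter) and no change at the digits printed from compound 1 to compound 3 (within the scatter) and no change at the digits printed from compound 2 to compound 3 (within the scatter) as their sizes. None of them brought in one six-membered aromatic ring of carbon only, so the precedent is limited. No step beyond the scatter is expected, and the estimated change is a 1.1-fold lower number from compound 3 to compound 4 (0.05 log units; within the scatter) in this assay overall. For compound 4 the expected value is 9000 nM with an estimated range of 3000 nM to 15000 nM here.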

Compound 4, half-maximal inhibitory concentration: 10000 nM
The estimate for compound 4 lay 1.1-fold (0.05 log units) below the measured number; the range from low to high includes it.
By their numbers in this assay, from the lowest: compounds 1, 2, 3 and 4 (each within the scatter of the next).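

In this assay, the first aromatic ring brought in at this place leaves the reading unmoved, with no change at the digits printed from compound 3 to compound 4 (within the scatter) and no change at the digits printed from compound 2 to compound 4 (within the scatter) as the sizes. The carbonyl can also stay while its substituent changes, as benzyloxy in place of diethylamino gives no change at the digits printed from compound 1 to compound 4 (within the scatter) and leaves the benzyloxycarbonyl and diethylcarbamoyl ends undistinguished. No evidence bears on this flat reading.
On these data alone, whether an amine or a carboxylic acid on this chain would move the number remains open, as does the effect of any change on the shared core.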